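The compounds below may be only part of what the source reports. "The series", "measured", "known", "first", "only" and "open" are said of these compounds alone.

Compounds measured so far:

Compound 1, `Cc1cc(NCc2ccccn2)n2ncc(-c3cccc(Cl)c3)c2n1`: < 5000 nM
Compound 2, `Cc1cc(NCc2ccccn2)n2ncc(-c3ccco3)c2n1`: 48800 nM

The two compounds share one core and differ only in the aryl group attached to it. In a physicochemical assay for solubility, read by HPLC, using the shake flask method, measured as kinetic solubility, with a stated time of 2 h, at pH 7.4 (a lower number here means a less soluble compound, a higher number a more soluble compound), compound 1 gives < 5000 nM, and this value is a limit of the assay rather than a number. In this assay, among the measured compounds shown here, compound 2 gives 48800 nM, which is the only number reported here. For the measured compounds named here, the one measured step, an at least 9.7-fold higher number from compound 1 to compound 2 (0.98 log units; beyond the scatter), is therefore known only as a lower bound, set by the limit of < 5000 nM in this assay, at which 1 of the 2 values shown sits.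

Compound 3, `Cc1cc(NCc2ccccn2)n2ncc(-c3ccsc3)c2n1`, carries thiophen-3-yl in place of furan-2-yl on an aromatic carbon. Going by the values given here, this exchange of one five-membered heteroaryl ring for another has no direct counterpart among the measured compounds: the only step recorded swaps a chlorophenyl ring for a furan, which is a different kind of change. With nothing closer to lean on, a step of at most modest size is expected, a 2.0-fold lower number from compound 2 to compound 3 (0.29 log units; within the scatter), and compound 3 is estimated to give 25000 nM, within a range of 8000 nM to 60000 nM.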

Compound 3, solubility: 9000 nM
Estimate against measurement, compound 3: 2.8-fold (0.44 log units) above; the range from low to high includes it.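

The change of one five-membered aromatic ring with 1 hetero atom for another, with the heavy-atom count and the counts of donors and acceptors the same, still matters at this aromatic carbon in this assay, giving a 5.4-fold lower number from compound 2 to compound 3 (0.73 log units; beyond the scatter). The earlier gain on leaving 3-chlorophenyl for furan-2-yl therefore does not carry over in full to every five-membered ring here, and the exchange of 3-chlorophenyl for thiophen-3-yl gives only an at least 1.8-fold higher number from compound 1 to compound 3 (0.25 log units; that floor lies within the scatter). Compound 1 stands at a limit and not at a number, so that step is known only as a floor: the limit of < 5000 nM in this assay, at which 1 of the 3 values shown sits.

The compounds shown leave open whether the difference between furan-2-yl and thiophen-3-yl follows the exchange of oxygen for sulfur or the different point of attachment, as the two change together and neither furan-3-yl nor thiophen-2-yl is among them. They also leave open how a ring carrying an amine or a carboxylic acid would read at this position in this assay.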